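Hydroxy removal on the saturated ring of compound 2

The source may hold more compounds than are shown below. What is called first, only, known or untested is meant among the compounds shown, and "the series" means these compounds.

Of the compounds shown here, two have been measured in an ADME assay on cell membranes for displacement of a labelled ligand from Sigma non-opioid intracellular receptor 1 (Cavia porcellus), read by scintillation counting, with a stated time of 120 min; a lower number here means a stronger inhibitor, a higher number a weaker inhibitor. Compound 1 `O=C(c1ccccc1)N1CCC(N2CCc3ccccc3C(O)C2)CC1` gives 800 nM. Compound 2 `OC1CN(Cc2ccc(-c3ccccc3)cc2)CCc2ccccc21` gives 230 nM in this assay, the lower of the two numbers, and its gap to compound 1 lies beyond the usual scatter. The two measured structures differ in several places at once, so no single structural change has yet been tied to a step in the numbers.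

Compound 3 `c1ccc(-c2ccc(CN3CCc4ccccc4CC3)cc2)cc1` is not yet measured in this assay. It differs from compound 2 in one place: hydrogen in place of hydroxy on a saturated ring carbon. Nothing in the two measured values shows how this change acts; the shared remainder of compound 2 stays in place.

The step from compound 2 to compound 3 is expected to be modest, toward a lower number and near the edge of the scatter, as a 2.1-fold lower number from compound 2 to compound 3 (0.32 log units; beyond the scatter). For compound 3 in this assay the expected value is 110 nM, with a range from 35 nM to 350 nM.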

Compound 3, inhibition constant: 16 nM
Compound 3: middle estimate off by 6.9-fold (0.84 log units), on the high side; the whole stated range lies above it.
By their numbers in this assay, from the lowest: compound 3; then compound 2; then compound 1.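

In this assay, going by these compounds alone, the hydroxy on a saturated ring carbon of the seven-membered non-aromatic ring, two ring bonds from the ring nitrogen, is the first single place to be tied to a step in the numbers. Hydrogen in place of this hydroxy gives a 14-fold lower number from compound 2 to compound 3 (1.16 log units; beyond the scatter) and that step lies beyond the scatter, so with the rest of compound 2 held in place, the loss of this one oxygen, with the hydrogen-bond donor and acceptor counted for the hydroxy, goes with a much stronger inhibitor. No measurement at hand bears on why the number falls when the hydroxy leaves.

On these data alone, the pair shows only hydroxy and hydrogen at this ring carbon, so it remains open whether a methoxy group, a fluorine atom or an amine in the same place would give a number closer to that of compound 2 or that of compound 3. As far as these compounds go, it also remains open whether hydrogen in place of hydroxy gives a step of similar size when the ring nitrogen carries the large group of compound 1.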